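Swapping the amide for a methylpiperazine on a bisbenzimidazole

The compounds below may be only part of what the source reports. "The series", "measured", "known", "first", "only" and "open" are said of these compounds alone.

Compound 1 `Cc1cccc(-c2nc3cc(-c4nc5cc(C(N)=O)ccc5[nH]4)ccc3[nH]2)c1`: 8200 nM
Compound 2 `NC(=O)c1ccc2[nH]c(-c3ccc4[nH]c(-c5ccc6ccccc6c5)nc4c3)nc2c1`: 740 nM

In a functional assay on RPMI 8402 cells (Homo sapiens) for cytotoxicity (a higher number here means a weaker inhibitor, a lower number a stronger inhibitor), compound 1 gives 8200 nM, the highest of the two numbers; the nearest is compound 2, with an 11-fold lower number from compound 1 to compound 2 (1.04 log units; beyond the scatter). Compound 3 `Cc1cccc(-c2nc3cc(-c4nc5cc(N6CCN(C)CC6)ccc5[nH]4)ccc3[nH]2)c1` differs from compound 1 by 4-methylpiperazin-1-yl in place of carbamoyl on an aromatic carbon. For the measured compounds named here, the only measured step, from compound 1 to compound 2, changes a different part of the shared core, so no measured step bears on this change, and its direction cannot be read from these data. Compound 3 is therefore expected to give about 6000 nM, within a wide range of 1500 nM to 25000 nM, an estimated step of a 1.4-fold lower number from compound 1 to compound 3 (0.14 log units; within the scatter).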

Compound 3, half-maximal inhibitory concentration: 360 nM
Compound 3: middle estimate off by 17-fold (1.22 log units), on the high side, and the stated range ends above it.
By their numbers in this assay, from the lowest: compound 3; then compound 2; then compound 1.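

Until now, only the 3-methylphenyl end had been varied, while the carbamoyl stayed fixed. Replacing carbamoyl with 4-methylpiperazin-1-yl gives a 23-fold lower number from compound 1 to compound 3 (1.36 log units; beyond the scatter) in this assay, so this second place on the shared core also strongly affects the read-out. Nothing shown explains this change in cytotoxicity.

As far as these compounds go, it remains open whether the piperazine ring or its methyl group matters more, which a plain piperazine or a morpholine at this position could help separate. Also open, from the compounds shown here alone, is how 4-methylpiperazin-1-yl would behave alongside naphthalen-2-yl on one molecule.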